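Phenoxy for Phenyl on a Longer Chain

The compounds below may be only part of what the source reports. "The series", "measured", "known", "first", "only" and "open" are said of these compounds alone.

Compound 1 `CC(C)(C)OC(=O)N1CCC[C@H]1COCCCCCC/C=C/c1ccc(-c2ccccc2)cc1` and compound 3 `CC(C)(C)OC(=O)N1CCC[C@H]1COCCCCCC/C=C/c1ccc(Oc2ccccc2)cc1` share one core, while compound 2 `CC(C)(C)OC(=O)N1CCC[C@H]1COCCCCCCCC/C=C/c1ccc(-c2ccccc2)cc1` and compound 4 `CC(C)(C)OC(=O)N1CCC[C@H]1COCCCCCCCC/C=C/c1ccc(Oc2ccccc2)cc1` share another; the difference between the two cores is not broken down here. In a functional assay on MIA PaCa-2 cells (Homo sapiens) for inhibition, read by MTT assay, with a stated time of 72 h (a higher number here means a weaker inhibitor, a lower number a stronger inhibitor), compound 1 gives 23000 nM and compound 3 gives 8500 nM, so the change phenoxy in place of phenyl on an aromatic carbon made the step of a 2.7-fold lower number from compound 1 to compound 3 (0.43 log units; beyond the scatter). Compound 2 gives 69200 nM in this assay, the highest of the three measured numbers. Compound 4 carries the same change on the core of compound 2, (phenoxy in place of phenyl on an aromatic carbon). Because the earlier step of a 2.7-fold lower number from compound 1 to compound 3 (0.43 log units; beyond the scatter) lay beyond the scatter, a step of similar size is expected from compound 2 to compound 4, a 2.7-fold lower number from compound 2 to compound 4 (0.43 log units; beyond the scatter). Compound 4 is therefore estimated at 26000 nM in this assay, most likely between 12000 nM and 55000 nM.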

Compound 4, half-maximal inhibitory concentration: > 100000 nM
Compound 4: no number, only a limit; the forecaster's own chance of this, stated with the estimate: 10%; middle value at least 3.8-fold (0.58 log units) away from the limit.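

The change did not carry over from one core to the other as a step of similar size: the same change on two cores in this assay, a 2.7-fold lower number (0.43 log units; beyond the scatter) from compound 1 to compound 3 and an at least 1.4-fold higher number (0.15 log units; that floor lies within the scatter) from compound 2 to compound 4, at least 3.9-fold (0.59 log units) apart, beyond the scatter of two such steps

Compound 4 gives > 100000 nM in this assay, which is a limit of the assay and not a number.

The new step is therefore only a floor, an at least 1.4-fold higher number from compound 2 to compound 4 (0.15 log units; that floor lies within the scatter), so these two pairs show that the outcome of the change depends on the core, but they show neither why nor the true size of the step.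

On these data alone, it remains open how phenoxy in place of phenyl would behave on a shorter chain. As far as these compounds go, it also remains open how an amine or a carboxylic acid would perform in that same place on the ring.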